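A few compounds are considered here, and "the series" means these few. Any claim that something is new, unique, unknown or untested is made for them only; others in the source may bear on it.

Compound 1, with the structure `Nc1nc(OCc2ccccc2)c2ncn(/C=C3/CC3(CO)CO)c2n1`, carries a benzyloxy group on the shared core. In an ADME assay on Akata cells (Homo sapiens) for cytotoxicity, with a stated time of 7 days (a lower number here means that less compound is tolerated, a higher number that more compound is tolerated), compound 1 gives > 20000 nM, which is a limit of the assay and not a measured number. Two companions share that core. Compound 2, `CC(C)Nc1nc(N)nc2c1ncn2/C=C1/CC1(CO)CO`, has isopropylamino in place of benzyloxy on an aromatic carbon, and in this assay compound 2 gives > 24000 nM, again a limit. Compound 3, `Nc1nc(NC2CCCCC2)c2ncn(/C=C3/CC3(CO)CO)c2n1`, has cyclohexylamino in place of benzyloxy on an aromatic carbon, and compound 3 gives > 24000 nM, also a limit. The steps between them, a step that the two limits leave unreadable from compound 1 to compound 2, a step that the two limits leave unreadable from compound 1 to compound 3 and a step that the two limits leave unreadable from compound 2 to compound 3, therefore cannot be read. So compound 1 stands where every compound shown stands: at a limit, as the limit of > 20000 nM in this assay, at which 1 of the 3 values shown sits, and the limit of > 24000 nM in this assay, at which 2 of the 3 values shown sit, make plain.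

Compound 4, `CCCCCCOc1nc(N)nc2c1ncn2/C=C1/CC1(CO)CO`, differs from compound 1 by pentyl in place of phenyl on a saturated chain carbon bound to an oxygen on an aromatic ring. Going by the values given here, none of the measured steps touches that part of the molecule, and none gives a readable size, so they set no direction for this change. Since every compound shown sits at a limit, compound 4 is expected to do the same, and the expected step is a step that the limit leaves unreadable from compound 1 to compound 4. The estimate for compound 4 is 25000 nM, with a range from 10000 nM to 60000 nM.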

Compound 4, half-maximal cytotoxic concentration: > 20000 nM
Compound 4: only a limit was reported (the forecaster's own chance of this, stated with the estimate: 80%); the middle value lies beyond the limit too.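

In this assay compound 4 gives > 20000 nM, which is a limit of the assay and not a measured number. Its steps from compound 1, compound 2 and compound 3 therefore cannot be read. The compounds shown leave open how much compound is actually tolerated, and whether hexyloxy in place of benzyloxy changes that at all.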